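This account rests on a few compounds, and the source may have more. Where it says the series, first, only, none or still open, it means among the compounds named here.

Working notes on the series in a functional assay on A-375 cells (Homo sapiens) for cytotoxicity, read by MTT assay, with a stated time of 72 h; a lower number here means a stronger inhibitor, a higher number a weaker inhibitor. Of the compounds shown here, three have numbers so far: compound 1 `CC1(C)OCC(Cn2cc(Cn3c4c(c5ccccc53)C(=O)c3c[n+]([O-])c5ccccc5c3C4=O)nn2)O1` gives 330 nM, compound 3 `CC1(C)OC[C@@H](Cn2cc(Cn3c4c(c5ccccc53)C(=O)c3c[n+]([O-])c5ccccc5c3C4=O)nn2)O1` gives 450 nM, and compound 2 `CN1CCN(CCCCn2c3c(c4ccccc42)C(=O)c2c[n+]([O-])c4ccccc4c2C3=O)CC1` gives 30 nM. Compound 2 has the lowest number of the three, and its gap to each of the other two lies beyond the scatter.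

Among the compounds with values here, the only measured step between closely matched compounds is a 1.4-fold higher number from compound 1 to compound 3 (0.13 log units; within the scatter), and what separates that pair is the fact that one of compounds 1 and 3 is drawn with a defined configuration and the other without, at the place where they differ. That step lies in a side chain that compound 2 does not carry, so it gives no guide to size here.

Compound 4 `CCCN1CCN(CCCCn2c3c(c4ccccc42)C(=O)c2c[n+]([O-])c4ccccc4c2C3=O)CC1` is the next to be read against compound 2. The change is ethyl in place of hydrogen on a saturated chain carbon bound to an amine nitrogen in a ring, which turns 4-methylpiperazin-1-yl into 4-propylpiperazin-1-yl. Within the data shown here, no measured step covers a change of this kind, so the only anchor is compound 2 at 30 nM. No shift beyond the scatter is expected in this assay, and the range is kept wide because no direct comparison exists at this place.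

The expected step is a 1.2-fold higher number from compound 2 to compound 4 (0.07 log units; within the scatter). For compound 4 the estimated value is 35 nM, with an expected range of 12 nM to 100 nM.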

Compound 4, half-maximal inhibitory concentration: 870 nM
Estimate against measurement, compound 4: 25-fold (1.40 log units) below; the measured number lies above the stated range.
By their numbers in this assay, from the lowest: compound 2; then compounds 1, 3 and 4 (each within the scatter of the next, the first and the last beyond it).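

In this assay, the change from 4-methylpiperazin-1-yl to 4-propylpiperazin-1-yl gives a 29-fold higher number from compound 2 to compound 4 (1.46 log units; beyond the scatter), so the added ethyl on a saturated chain carbon bound to an amine nitrogen in a ring is far from a neutral change in this series. Within the data shown here, this is the first step between closely matched compounds to lie beyond the scatter, and it shows that the low number of compound 2, at 30 nM, does not carry over to every close relative with the same core and the same chain to the ring. The compounds shown hold no measurement that explains this step, and the only available observation concerns a different side chain and a difference in drawn configuration.

The compounds shown leave open whether the number rises gradually or abruptly with chain length, a question that 4-ethylpiperazin-1-yl would help to settle. They also leave open whether any group larger than methyl behaves the same way at this place, or whether a 4-(2-hydroxyethyl)piperazin-1-yl or an unsubstituted piperazin-1-yl would read differently.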